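The source may hold more compounds than are shown below. What is called first, only, known or untested is meant among the compounds shown, and "the series" means these compounds.

Measured compounds:
Compound 1 `O=c1[nH]c(=O)n([C@H]2C[C@H](O)[C@@H](CO)O2)cc1/C=C/I` gives 63900 nM in an ADME assay on L1210/0 cells (Mus musculus) for cytotoxicity, with a stated time of 48 h; a higher number here means a weaker inhibitor, a lower number a stronger inhibitor.
Compound 2 `C=C(Cl)c1cn([C@H]2C[C@H](O)[C@@H](CO)O2)c(=O)[nH]c1=O` gives 1660 nM in this assay.
Compound 3 `O=c1[nH]c(=O)n([C@H]2C[C@H](O)[C@@H](CO)O2)cc1C#CCCO` reaches only the assay limit, > 200000 nM, in this assay.

Compound 3 thus stands at the weak end of the three, and its value is a limit rather than a number, as marked by the limit of > 200000 nM in this assay, at which 1 of the 3 values shown sits. The step of interest leads to compound 4 `CCCC/C=C\c1cn([C@H]2C[C@H](O)[C@@H](CO)O2)c(=O)[nH]c1=O`, which is not yet measured. The change is hex-1-en-1-yl in place of 4-hydroxybut-1-yn-1-yl on an aromatic carbon. Within the data shown here, two measured steps bear on it: an at least 120-fold higher number from compound 2 to compound 3 (2.08 log units; beyond the scatter) and an at least 3.1-fold higher number from compound 1 to compound 3 (0.49 log units; beyond the scatter). Both show that the 4-hydroxybut-1-yn-1-yl group goes with the weakest value, while the two haloalkenyl compounds give lower numbers. Compound 4 carries a hex-1-en-1-yl group, which shares the double bond with compounds 1 and 2 but lacks their halogen, so the step is expected to run toward a lower number, though by how much is uncertain. For compound 4 the expected step is an at least 4.0-fold lower number from compound 3 to compound 4 (0.60 log units; beyond the scatter), giving an estimate of 50000 nM with a range from 5000 nM to 200000 nM.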

Compound 4, half-maximal inhibitory concentration: > 200000 nM
Compound 4: a limit, no number (the forecaster's own chance of this, stated with the estimate: 30%); middle value at least 4.0-fold (0.60 log units) away from the limit.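

In this assay, compound 4 gives only a limit, and it is the second compound to do so: the limit of > 200000 nM in this assay, at which 2 of the 4 values shown sit A double bond on this aromatic carbon is therefore not enough for a low number, as hex-1-en-1-yl, which carries no halogen, gives an at least 120-fold higher number from compound 2 to compound 4 (2.08 log units; beyond the scatter) and an at least 3.1-fold higher number from compound 1 to compound 4 (0.49 log units; beyond the scatter). Among the compounds shown, only the two haloalkenyl groups give a measured number, while the step between the 4-hydroxybut-1-yn-1-yl and hex-1-en-1-yl groups cannot be read, as both values are limits.

The compounds shown leave open whether the missing halogen or the longer chain separates compound 4 from compound 1 and compound 2. An unsubstituted ethenyl group or a 1-bromoethenyl group at this position would bear on that question.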